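Carboxy for Hydrogen on the Shared Core

A few compounds are considered here, and "the series" means these few. Any claim that something is new, unique, unknown or untested is made for them only; others in the source may bear on it.

Compound 1 `CN1CCN(c2ccc(/C=C/C(=O)c3cn(C)c4ccccc34)cc2)CC1` gives 11700 nM in a functional assay on RT-112 cells (Homo sapiens) for antiproliferative activity, read by MTT assay, with a stated time of 48 h; on this read-out higher numbers stand for weaker inhibition and lower numbers for stronger inhibition.
Compound 2 `COc1cc(OC)c(/C=C/C(=O)c2cn(C)c3ccccc23)c(OC)c1` gives 3200 nM in this assay.

Of the two measured compounds, compound 2 stands at the lowest number in this assay. Within the data shown here, its only neighbour, compound 1, gives the higher number, and the gap between the two lies beyond the usual scatter of repeated measurements, so compound 2 is the stronger inhibitor of the pair.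

Compound 3 `COc1cc(OC)c(/C=C/C(=O)c2cn(C)c3ccc(C(=O)O)cc23)c(OC)c1` is not yet measured. It differs from compound 2 in one place: carboxy in place of hydrogen on an aromatic carbon. Among the measured compounds shown here, no step of this kind appears between the two measured compounds, so nothing measured here shows how such a change moves the number. The account therefore expects a modest move in compound 3 toward a higher number, that is toward weaker inhibition, of a size that may or may not exceed the scatter. Compound 3 is expected to give about 6000 nM in this assay, within a range from 2500 nM to 15000 nM. This estimate corresponds to an expected step of a 1.9-fold higher number from compound 2 to compound 3 (0.27 log units; within the scatter).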

Compound 3, half-maximal inhibitory concentration: 86100 nM
Compound 3: middle estimate off by 14-fold (1.16 log units), on the low side; the whole stated range lies below it.
By their numbers in this assay, from the lowest: compound 2; then compound 1; then compound 3.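

In this assay, carboxy in place of hydrogen on this aromatic carbon, part of a fused system of two rings, gives a 27-fold higher number from compound 2 to compound 3 (1.43 log units; beyond the scatter), a large step toward weaker inhibition. The shared core with the trimethoxy-substituted ring of compound 2 is therefore not indifferent to what stands at this position: one change here, bringing in 3 heavy atoms with one hydrogen-bond donor, one hydrogen-bond acceptor and no net charge, moves the number well beyond the usual scatter. Nothing in the data shown explains why the number moves so far.

The compounds shown leave open whether a methyl ester, a primary amide or a hydroxymethyl group on the same aromatic carbon would give a number closer to that of compound 2 or to that of compound 3. They also leave open whether a carboxylic acid on another carbon of that ring, or on the same carbon of compound 1, would bring a step of similar size.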